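Methyl for chloro on the anilide ring of a quinolinol amide

This account rests on a few compounds, and the source may have more. Where it says the series, first, only, none or still open, it means among the compounds named here.

Of the compounds shown here, three share the same aryl-amide arrangement and have been tested in a functional assay on NALM-6 cells (Homo sapiens) for cytotoxicity, read by luminescence and CellTiter-Glo, with a stated time of 3 days; a higher number here means a weaker inhibitor, a lower number a stronger inhibitor. Compound 1 `O=C(Nc1ccc(C(F)(F)F)cc1)c1cc(Cl)c(-c2ccccc2)cc1O` gives 800 nM. Compound 2 `N#Cc1ccc(NC(=O)c2ccc3cccnc3c2O)c(Cl)c1` gives 420 nM. Compound 3 `O=C(Nc1ccc(C(F)(F)F)cc1)c1ccc2cccnc2c1O` gives 380 nM. Compound 2 sits as the second highest of these three numbers; its nearest neighbour is compound 3, and its furthest is compound 1, yet both of those gaps lie within the usual scatter of this assay, so the three values cannot be placed in any reliable order.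

The next compound, compound 4 `Cc1cc(C#N)ccc1NC(=O)c1ccc2cccnc2c1O`, differs from compound 2 in one place: methyl in place of chloro on an aromatic carbon. The cyano group and the rest of the core are untouched.

Within the data shown here, no measured pair in this set isolates this particular change, so its effect can only be guessed from the closeness of all three values so far. Since the anilide substituents in compounds 1, 2 and 3 vary without moving the numbers beyond the scatter, the account expects no step beyond the scatter either way, with the estimated step being a 1.2-fold higher number from compound 2 to compound 4 (0.08 log units; within the scatter).

For compound 4 the expected value in this assay is 500 nM, with a range of 200 nM to 1300 nM.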

Compound 4, half-maximal inhibitory concentration: 230 nM
Estimate against measurement, compound 4: 2.2-fold (0.34 log units) above; low and high end bracket the measured number.
By their numbers in this assay, from the lowest: compounds 4, 3, 2 and 1 (each within the scatter of the next, the first and the last beyond it).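

In this assay, among these compounds, the exchange of chloro for methyl on an aromatic carbon, ortho to a large group and meta to a cyano group, gives a 1.8-fold lower number from compound 2 to compound 4 (0.26 log units; within the scatter) and is the first step in this set that isolates a single place. The earlier compounds shown here differ in more than one place, so they could only suggest that the anilide substituents matter little, whereas this matched pair tests that idea directly at this position: chloro and methyl cannot be told apart here beyond the usual scatter of repeated measurements, and the pair gives no ground for preferring either group. No measurement at hand bears on why the two numbers stand where they do.

What the compounds shown leave open is whether this position accepts groups of a different kind, such as an amine, a methoxy group or a longer chain, or plain hydrogen on the same carbon. They also leave open whether the exchange of chloro for methyl would read the same if the cyano group gave way to a carboxylic acid.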